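Trifluoromethyl replaces methyl on the benzyloxy tetralone

The source may report more compounds than this note shows. Statements on the series, on what has been measured and on what is new or still open speak of the compounds shown alone.

The series was studied in an assay on isolated protein for inhibition of Amine oxidase [flavin-containing] B (Homo sapiens), read by fluorescence and spectrophotometry, with a stated time of 30 min; on this read-out higher numbers stand for weaker inhibition and lower numbers for stronger inhibition. Compound 1, `O=C1CCCc2cc(OCc3cccc(Cl)c3)ccc21`, gives 15 nM in this assay. Compound 2, `Cc1ccc(COc2ccc3c(c2)CCCC3=O)cc1`, gives 11 nM in this assay; it shows the lowest of the two numbers, and its nearest neighbour is compound 1, whose value lies within the usual scatter, so no order between the two can be claimed. Compound 3, `O=C1CCCc2cc(OCc3ccc(C(F)(F)F)cc3)ccc21`, has not been measured. It differs from compound 2 by trifluoromethyl in place of methyl on an aromatic carbon; the change is trifluoromethyl in place of methyl on an aromatic carbon, para to a large group. Within the data shown here, no measured pair in the set shows such a swap, so the expected step from compound 2 to compound 3 is put at a 1.8-fold higher number from compound 2 to compound 3 (0.26 log units; within the scatter), which is expected to stay within or just beyond the scatter and to point toward a somewhat higher number. Compound 3 is therefore estimated to give 20 nM in this assay, with a range from 6 nM to 70 nM.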

Compound 3, half-maximal inhibitory concentration: 6 nM
For compound 3 the middle estimate is 3.3-fold (0.52 log units) above the measured one; the measured number falls inside the stated range.
By their numbers in this assay, from the lowest: compounds 3, 2 and 1 (each within the scatter of the next, the first and the last beyond it).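

In this assay, among these compounds, trifluoromethyl in place of methyl on an aromatic carbon, para to a large group, gives a 1.8-fold lower number from compound 2 to compound 3 (0.26 log units; within the scatter) and is the first single-place step available. It shows that this position accepts trifluoromethyl as well as methyl, with the two numbers too close for any order to be claimed between them. Nothing measured here accounts for this result.

The compounds shown leave open how an amine, a carboxylic acid or a methoxy group would read on this same carbon. With only methyl and trifluoromethyl compared here, they also do not show whether a hydrogen or a nitrile at this place would stay as close, or how far this position's tolerance extends.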